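Trading a phenyl for an isopentyl chain

The source may hold more compounds than are shown below. What is called first, only, known or untested is meant among the compounds shown, and "the series" means these compounds.

In a functional assay on a cell-free system (plasma, Homo sapiens), with a stated time of 3 min (on this read-out lower numbers stand for stronger inhibition and higher numbers for weaker inhibition), compound 1 `O=C(NCc1cc(Cl)ccc1-n1cnnn1)[C@@H]1CC=NN1C(=O)[C@H](O)c1ccccc1` gives 840 nM. Two other measured compounds lie within the usual scatter of that number: compound 2 `CC(C)(C)[C@@H](O)C(=O)N1C[C@@H]2C[C@@H]2[C@H]1C(=O)NCc1cc(Cl)ccc1-n1cnnn1` gives 570 nM and compound 3 `O=C(NCc1cc(Cl)ccc1-n1cnnn1)[C@@H]1C[C@H]2C[C@H]2N1C(=O)[C@H](O)CC1CC1` gives 850 nM. Compound 1 therefore stands level with both.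

Compound 4 `CC(C)CC[C@@H](O)C(=O)N1N=CC[C@H]1C(=O)NCc1cc(Cl)ccc1-n1cnnn1` keeps the core of compound 1 and changes one group, with isopentyl in place of phenyl on a saturated chain carbon bound to a carbonyl carbon and an oxygen on a saturated carbon. Going by the values given here, no measured pair shows this swap on its own, so any forecast is uncertain. The closest guide is that compound 2 has a saturated group instead of phenyl there and gives 570 nM, and compound 3 likewise gives 850 nM, although both also differ from compound 1 elsewhere. No step beyond the scatter is therefore expected in this assay, in either direction. The estimated step is a 1.1-fold lower number from compound 1 to compound 4 (0.02 log units; within the scatter). The expected value for compound 4 is 800 nM, with an estimated range of 300 nM to 2400 nM.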

Compound 4, half-maximal inhibitory concentration: 630 nM
For compound 4 the middle estimate is 1.3-fold (0.10 log units) above the measured one, within the range that was stated.
By their numbers in this assay, from the lowest: compounds 2, 4, 1 and 3 (each within the scatter of the next).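

Swapping phenyl for isopentyl on this core gives a 1.3-fold lower number from compound 1 to compound 4 (0.12 log units; within the scatter) in this assay, and this is the only pair shown in which that group alone changes. On this saturated chain carbon, then, the six-membered aromatic ring can give way to an open chain with no ring, with no step beyond the scatter on this read-out, so the ring is not shown to be needed here. Nothing measured here explains why the two groups read alike.

From the compounds shown here alone, both groups contain carbon only, so how an amine or a carboxylic acid would read at this position remains open. A single swap on one core also cannot show whether a longer chain would fit the same picture, or whether the swap would read the same way on another core.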